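The source may report more compounds than this note shows. Statements on the series, on what has been measured and on what is new or still open speak of the compounds shown alone.

Working notes on a set of stereoisomers sharing one core. Compound 1 `O=C(O)[C@H]1NC[C@@H](O)[C@H](O)[C@H]1O` and compound 2 `O=C(O)[C@H]1NC[C@H](O)[C@@H](O)[C@@H]1O` have been measured in an assay for inhibition of alpha-N-acetylgalactosaminidase (Gallus gallus), tested at 1000 uM; a lower number here means less inhibition, a higher number more inhibition at the concentration tested (going by the name of the read-out). In this assay compound 1 gives 4.2%, and compound 2 gives 0.2%. Compound 2 thus stands lowest of the two numbers, with compound 1 its nearest neighbour, but the step of a number 4 percentage points lower from compound 1 to compound 2 (within the scatter) does not exceed the usual scatter, so no order between the two can be read from it. The two compounds are the same in every atom and bond and differ only in configuration as drawn (the fact that compounds 1 and 2 differ only in the configuration as drawn).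

Compound 3 `O=C(O)[C@@H]1NC[C@@H](O)[C@@H](O)[C@H]1O` is still to be measured in this assay. It differs from compound 2 as follows: the two compounds have the same atoms and bonds and differ only in configuration as drawn: 3 of 4 stereo elements differ; a stereocentre at a saturated ring carbon is drawn S in compound 2 and R in compound 3; a stereocentre at a saturated ring carbon is drawn S in compound 2 and R in compound 3; a stereocentre at a saturated ring carbon is drawn R in compound 2 and S in compound 3. Going by the values given here, the only measured step of the same kind, a number 4 percentage points lower from compound 1 to compound 2 (within the scatter), is likewise a change in configuration alone and lies within the scatter, so it gives no direction to build on. On that basis the step of a number 2.8 percentage points higher from compound 2 to compound 3 (within the scatter) is expected to stay within the scatter. The estimate for compound 3 in this assay is 3%, with a range from 0% to 12%.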

Compound 3, a percentage reported as inhibition, at one concentration (the size of the read-out at that concentration, not a potency): 8.2%
For compound 3 the middle estimate is 5.2 percentage points below the measured one; the measured number falls inside the stated range.
By their numbers in this assay, from the lowest: compounds 2, 1 and 3 (each within the scatter of the next).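

With compound 3, this assay now covers a third arrangement of the stereocentres on the shared core, and both new steps, a number 8 percentage points higher from compound 2 to compound 3 (within the scatter) and a number 4 percentage points higher from compound 1 to compound 3 (within the scatter), lie within the scatter, so the three compounds cannot be placed in any order. Going by these compounds alone, the earlier pair showed this for only one change of three stereocentres; the series now adds a second change of three and a change of two, and neither separates the compounds at the concentration tested. Along these steps the atoms and bonds stay the same, so configuration is the only variable in play: the fact that compounds 2 and 3 differ only in the configuration as drawn

Still open, as far as these compounds go, is whether any other arrangement of the stereocentres on this core would give a number that stands clear of these three. Also open, from the compounds shown here alone, is whether a methyl ester or an amide in place of the carboxylic acid, or a longer chain on the amine, would produce a step beyond the scatter in this assay.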